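Imidazopyrazine benzimidazoles: ortho-fluoro analogue of compound 3

This account rests on a few compounds, and the source may have more. Where it says the series, first, only, none or still open, it means among the compounds named here.

Measured so far:
compound 1 `COc1ccc(-c2cn3ccnc3c(-c3ccc4ncn(C5CCCCC5)c4c3)n2)cc1` — 92.5%
compound 2 `Fc1ccc(-c2cn3ccnc3c(-c3ccc4ncn(C5CCCCC5)c4c3)n2)cc1` — 7.93%
compound 3 `COc1ccccc1-c1cn2ccnc2c(-c2ccc3ncn(C4CCCCC4)c3c2)n1` — 9.76%

In a functional assay on SF-295 cells (Homo sapiens) for inhibition, read by sulforhodamine B assay, with a stated time of 48 h, tested at 10 uM (on this read-out lower numbers stand for less inhibition and higher numbers for more inhibition at the one concentration tested (going by the name of the read-out)), compound 1 gives 92.5%. The change to compound 2 is fluoro in place of methoxy on an aromatic carbon, and it gives a number 84.6 percentage points lower from compound 1 to compound 2 (beyond the scatter). The change to compound 3 is 2-methoxyphenyl in place of 4-methoxyphenyl on an aromatic carbon, with a number 82.7 percentage points lower from compound 1 to compound 3 (beyond the scatter). Between compounds 2 and 3 the values lie close together, a number 1.8 percentage points higher from compound 2 to compound 3 (within the scatter), so nothing separates them.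

Compound 4 `Fc1ccccc1-c1cn2ccnc2c(-c2ccc3ncn(C4CCCCC4)c3c2)n1` is not yet measured in this assay. Its difference from compound 3 is fluoro in place of methoxy on an aromatic carbon. This is the same kind of change as that from compound 1 to compound 2, though the place differs: there the fluoro enters para to a large group, here ortho to a large group. The earlier step was large, but it started from the high value of compound 1; compound 3 starts from 9.76%, already a low number on the read-out, and compound 2 shows that a fluorophenyl analogue in this series sits at 7.93%. The expected step from compound 3 to compound 4 is therefore small, about a number 1.8 percentage points lower from compound 3 to compound 4 (within the scatter), within the scatter, because compound 3 at 9.76% leaves little room for a further fall. Compound 4 is estimated at 8% in this assay, with a range from 0% to 25%.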

Compound 4, a percentage reported as inhibition, at one concentration (the size of the read-out at that concentration, not a potency): 10.4%
The estimate for compound 4 lay 2.4 percentage points below the measured number; the range from low to high includes it.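

In this assay, fluoro in place of methoxy gives a number 0.6 percentage points higher from compound 3 to compound 4 (within the scatter), so the step seen with the 4-methoxyphenyl compound does not carry over to the 2-methoxyphenyl compound: the same change on two cores in this assay, a number 84.6 percentage points lower (beyond the scatter) from compound 1 to compound 2 and a number 0.6 percentage points higher (within the scatter) from compound 3 to compound 4, 85.2 percentage points apart, beyond the scatter of two such steps

Compound 4 also lies close to the other fluoro compound, with a number 2.5 percentage points higher from compound 2 to compound 4 (within the scatter), and far from the 4-methoxyphenyl compound, with a number 82.1 percentage points lower from compound 1 to compound 4 (beyond the scatter); among the four compounds shown, only compound 1 gives a high number. These results do not show why the two steps differ, and with a single pair on each side, each read at one concentration, they give no rule for any other pair in the series.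

Going by these compounds, it remains open whether the high number of compound 1 is specific to methoxy at that place or would persist with an ethoxy group, a dimethylamino group or a carboxylic acid there. Going by these compounds alone, it also remains open whether the 2-substituted compounds stay low with such groups, since compound 3 and compound 4 are the only two examples of that arrangement.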